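Cytotoxicity of Two Amine Variants Stays Beyond the Limit

The source may hold more compounds than are shown below. What is called first, only, known or untested is meant among the compounds shown, and "the series" means these compounds.

compound 1 `CC(C)(O)CNc1c(-c2ccccn2)nc2ccccn12`: > 50000 nM
compound 2 `c1ccc(CNc2c(-c3ccccn3)nc3ccccn23)cc1`: > 50000 nM

In an ADME assay on THP-1 cells (Homo sapiens) for cytotoxicity (on this read-out higher numbers stand for lower toxicity in this test and lower numbers for higher toxicity in this test), compound 1 gives > 50000 nM, which is a limit of the assay rather than a measured number. In this assay compound 2 gives > 50000 nM, again only a limit. The step that the two limits leave unreadable from compound 1 to compound 2 cannot be sized because the limit of > 50000 nM in this assay, at which 2 of the 2 values shown sit, holds both values, so compound 2 is known only to sit at that limit, as does compound 1.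

Compound 3 `COc1ccccc1Nc1c(-c2ccccn2)nc2ccccn12` differs from compound 2 in one place: 2-methoxyphenyl in place of benzyl on a nitrogen on an aromatic ring. For the measured compounds named here, no measured step covers this change, and the single step that is available is unreadable. With both neighbours at the limit, no shift beyond the usual scatter is expected, and the step that the limit leaves unreadable from compound 2 to compound 3 is therefore estimated to be essentially flat. Compound 3 is expected to give about 60000 nM in this assay, within a range of 25000 nM to 150000 nM, most likely again reported only as a limit.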

Compound 3, half-maximal cytotoxic concentration: > 50000 nM
Compound 3 gave a limit, no number (the forecaster's own chance of this, stated with the estimate: 80%); the middle value lies beyond the limit too.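

No step can be read among compound 1, compound 2 and compound 3, as all three results are limits of the assay and not numbers: the limit of > 50000 nM in this assay, at which 3 of the 3 values shown sit.

Left open is how far each compound lies past that limit, and whether changing the group on the nitrogen shifts the result in this assay at all.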